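The compounds below may be only part of what the source reports. "The series", "measured", "known", "first", "only" and "open" are said of these compounds alone.

Working notes on the series.

Compound 1 `Cc1cc2nc(-c3ccco3)n(-c3ccc4c(N)nc(N)nc4c3)c2cc1C` is the reference point: in an assay on isolated protein for inhibition of Dihydrofolate reductase (Homo sapiens), read by spectrophotometry, using NADPH, with a stated time of 10 min (on this read-out lower numbers stand for stronger inhibition and higher numbers for weaker inhibition), compound 1 gives 943 nM. Compound 2 `Cc1cc2nc(-c3cccn3C)n(-c3ccc4c(N)nc(N)nc4c3)c2cc1C` carries 1-methyl-1H-pyrrol-2-yl in place of furan-2-yl on an aromatic carbon. For compound 2 the read-out is a limit of the assay rather than a number, > 5000 nM. The step of an at least 5.3-fold higher number from compound 1 to compound 2 (0.72 log units; beyond the scatter) is therefore only a lower bound on the loss, because the limit of > 5000 nM in this assay, at which 1 of the 2 values shown sits, caps what can be said about compound 2; compound 2 stands at the weak end of the two numbers shown.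

Compound 3 `Cc1cc2nc(C3CCOC3)n(-c3ccc4c(N)nc(N)nc4c3)c2cc1C` is the next member. The change is oxolan-3-yl in place of 1-methyl-1H-pyrrol-2-yl on an aromatic carbon. Within the data shown here, no measured step covers this kind of exchange: the only step in hand, an at least 5.3-fold higher number from compound 1 to compound 2 (0.72 log units; beyond the scatter), swaps one five-membered aromatic ring for another, whereas here an aromatic ring leaves and a non-aromatic one enters. Direction and size of the step in this assay are thus open, and compound 2 being a limit leaves the baseline itself uncertain. Compound 3 is estimated at 3000 nM, with a range of 800 nM to 10000 nM, which would mean a step of an at least 1.6-fold lower number from compound 2 to compound 3 (0.22 log units; that floor lies within the scatter).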

Compound 3, inhibition constant: > 5000 nM
Compound 3: only a limit was reported; the forecaster's own chance of this, stated with the estimate: 40%; middle value at least 1.6-fold (0.22 log units) from the limit.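

In this assay compound 3 also gives a limit of the assay rather than a number, > 5000 nM, so a non-aromatic ring at this position, between two ring nitrogen atoms, yields no measurable inhibition within the assay's range, just as 1-methyl-1H-pyrrol-2-yl did. Oxolan-3-yl in place of furan-2-yl gives an at least 5.3-fold higher number from compound 1 to compound 3 (0.72 log units; beyond the scatter), which shows that the loss at this position is not confined to one aromatic replacement, and among the three groups shown only furan-2-yl gives a measured number. As far as these compounds go, the step between compound 2 and compound 3 cannot be read, and their order remains unknown because both sit at the ceiling of the read-out: the limit of > 5000 nM in this assay, at which 2 of the 3 values shown sit.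

The compounds shown leave open how far compound 2 and compound 3 lie past that limit, and therefore whether the aromatic or the non-aromatic ring is the poorer of the two. They also leave open whether any other group at this position, such as thiophen-2-yl, phenyl, an open alkyl chain or an amine, would match or improve on furan-2-yl.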